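Adding a methoxy group to compound 2

The source may report more compounds than this note shows. Statements on the series, on what has been measured and on what is new or still open speak of the compounds shown alone.

Measured in an in vitro ADME assay on microsomes from liver (Homo sapiens) for metabolic stability; a lower number here means slower removal, a higher number faster removal of the compound:
Compound 1 `COc1cccc(C(=O)N2CCC(=CC(=O)N[C@@H]3CCN(Cc4ccc5cc(F)ccc5c4)C3)CC2)c1`: 500 mL/min/kg
Compound 2 `O=C(C=C1CCN(C(=O)c2ccccc2O)CC1)N[C@@H]1CCN(Cc2ccc3cc(F)ccc3c2)C1`: < 64 mL/min/kg

Compound 2 stands at the limit of < 64 mL/min/kg in this assay, at which 1 of the 2 values shown sits, so its result is a limit and not a number. Compound 3 `COc1cccc(O)c1C(=O)N1CCC(=CC(=O)N[C@@H]2CCN(Cc3ccc4cc(F)ccc4c3)C2)CC1` differs from it by methoxy in place of hydrogen on an aromatic carbon. Among the measured compounds shown here, only one measured step bears on this change, and only in part: an at least 7.8-fold lower number from compound 1 to compound 2 (0.89 log units; beyond the scatter). That step replaced 3-methoxyphenyl with 2-hydroxyphenyl and lies beyond the scatter. Compound 3 keeps the hydroxy group and gains a methoxy group, and compound 1, which also has a methoxy group, gives 500 mL/min/kg, so a modest rise is expected. The expected change is an at least 1.1-fold higher number from compound 2 to compound 3 (0.06 log units; that floor lies within the scatter). Compound 3 is estimated at 75 mL/min/kg, with an expected range of 40 mL/min/kg to 250 mL/min/kg.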

Compound 3, clearance: 192 mL/min/kg
Compound 3: middle estimate off by 2.6-fold (0.41 log units), on the low side; low and high end bracket the measured number.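

In this assay, methoxy on this aromatic carbon of the 2-hydroxyphenyl group gives an at least 3.0-fold higher number from compound 2 to compound 3 (0.47 log units; beyond the scatter), so the hydroxy group alone does not keep the number low. The 2-hydroxy-6-methoxyphenyl group still gives a 2.6-fold lower number from compound 1 to compound 3 (0.42 log units; beyond the scatter), which places its result between those of the other two groups. The result for compound 2 is a limit of the assay and not a number, so the full size of the rise remains unknown: the limit of < 64 mL/min/kg in this assay, at which 1 of the 3 values shown sits.

Going by these compounds, what stays open is whether an ethoxy group, a fluorine atom or an amine on this carbon would give a similar rise. The compounds shown also leave open whether methoxy on another carbon of this ring would do the same.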